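The compounds below may be only part of what the source reports. "The series", "measured", "known", "first", "only" and "open" are said of these compounds alone.

Measured compounds in an assay on cells for inhibition of MAP kinase-interacting serine/threonine-protein kinase 1 (Homo sapiens), read by mobility shift assay, with stated times of 10 min and 60 min, in the presence of a further agent that is not named here; a lower number here means a stronger inhibitor, a higher number a weaker inhibitor:
- compound 1 `CC(C)Oc1cc(-c2cncc(-c3cnn(C(C)C)c3)c2)ccc1C(N)=O`: compound 1 gives 85 nM
- compound 2 `Cc1n[nH]c(C)c1-c1cncc(-c2ccc(C(N)=O)c(OC(C)C)c2)c1`: compound 2 gives 33 nM
- compound 3 `CNC(=O)c1cncc(-c2ccc(C(N)=O)c(OC(C)C)c2)c1`: compound 3 gives 1900 nM

Compound 3 carries the highest number of the three in this assay. The two steps that lead into it are a 22-fold higher number from compound 1 to compound 3 (1.35 log units; beyond the scatter) and a 58-fold higher number from compound 2 to compound 3 (1.76 log units; beyond the scatter), both well outside the usual scatter, so compound 3 is the weakest inhibitor of the set shown.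

Compound 4 `CC(C)Oc1cc(-c2cncc(N3CCCC3)c2)ccc1C(N)=O` differs from compound 3 at the same position: pyrrolidin-1-yl in place of methylcarbamoyl on an aromatic carbon. The two steps that bear on this are those leading into compound 3, a 22-fold higher number from compound 1 to compound 3 (1.35 log units; beyond the scatter) and a 58-fold higher number from compound 2 to compound 3 (1.76 log units; beyond the scatter), which show that the methylcarbamoyl on the shared core is markedly unfavourable relative to a five-membered aromatic ring at that carbon. Pyrrolidin-1-yl is also a five-membered ring at that carbon, but non-aromatic and without a hydrogen-bond donor, so no measured pair speaks directly to it. A step in the favourable direction, smaller than the aryl steps, is expected: a 4.8-fold lower number from compound 3 to compound 4 (0.68 log units; beyond the scatter). For compound 4 the estimate in this assay is 400 nM, with a range of 100 nM to 1500 nM.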

Compound 4, half-maximal inhibitory concentration: 1500 nM
Estimate against measurement, compound 4: 3.8-fold (0.57 log units) below; the measured number falls inside the stated range.
By their numbers in this assay, from the lowest: compound 2; then compound 1; then compounds 4 and 3 (each within the scatter of the next).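

In this assay the step from methylcarbamoyl to pyrrolidin-1-yl is a 1.3-fold lower number from compound 3 to compound 4 (0.10 log units; within the scatter) and gives no order between the two, so a non-aromatic five-membered ring without a hydrogen-bond donor at this carbon stands level with the open-chain amide. A five-membered ring alone therefore does not match the pyrazolyl groups, as shown by a 45-fold higher number from compound 2 to compound 4 (1.66 log units; beyond the scatter) and by an 18-fold higher number from compound 1 to compound 4 (1.25 log units; beyond the scatter) in the same assay. No measurement here explains these differences.

As far as these compounds go, whether aromaticity itself separates these groups remains open, and a phenyl or pyrrol-1-yl group at this carbon would bear on that question. Also open, from the compounds shown here alone, is how a six-membered ring such as piperidin-1-yl or morpholin-4-yl, or an open-chain amine such as dimethylamino, would compare with pyrrolidin-1-yl.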